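Trifluoromethyl on the anilino ring of compound 2

The source may report more compounds than this note shows. Statements on the series, on what has been measured and on what is new or still open speak of the compounds shown alone.

Measured compounds:
- compound 2, `N=C(Nc1ccccc1)c1cc2c(-c3ccccc3)n[nH]c2c(NC2CCCCC2)n1`: 850 nM
- compound 3, `COc1ccc(Cn2nc(-c3ccccc3)c3cc(C(=N)Nc4ccccc4)nc(NC4CCCCC4)c32)cc1`: 3400 nM
- compound 1, `COc1ccc(Cn2nc(-c3ccccc3)c3cc(C(=N)Nc4cccc(C(F)(F)F)c4)nc(NC4CCCCC4)c32)cc1`: "not determined" (no result reported)

The shared core carries a phenyl group, a cyclohexylamino group and an amidine that links to an anilino ring. In a functional assay on HT-1080 cells (Homo sapiens) for cytotoxicity, read by MTT assay, with a stated time of 72 h (a lower number here means a stronger inhibitor, a higher number a weaker inhibitor), compound 2 gives 850 nM, the lowest of the two numbers available. Compound 3 differs from compound 2 only by a 4-methoxybenzyl group in place of hydrogen on an aromatic nitrogen, and that change gave a 4.0-fold higher number from compound 2 to compound 3 (0.60 log units; beyond the scatter). Compound 1 carries both that 4-methoxybenzyl group and a trifluoromethyl group on the anilino ring, but no number was reported for it.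

Compound 4, `N=C(Nc1cccc(C(F)(F)F)c1)c1cc2c(-c3ccccc3)n[nH]c2c(NC2CCCCC2)n1`, keeps the free aromatic nitrogen of compound 2 and changes only the anilino ring: trifluoromethyl in place of hydrogen on an aromatic carbon. None of the measured steps tests this particular change, since the only measured step concerns the aromatic nitrogen, and compound 1, which would have shown the same change in the benzylated series, has no result. With nothing to point in either direction, the expectation for compound 4 in this assay is a step of no change at the digits printed from compound 2 to compound 4 (within the scatter), that is, no change beyond the scatter. Compound 4 is therefore expected to give about 850 nM, with a range from 300 nM to 2500 nM.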

Compound 4, half-maximal inhibitory concentration: 21200 nM
Beside the measured number, compound 4's estimate is 25-fold (1.40 log units) below it; the whole stated range lies below it.
By their numbers in this assay, from the lowest: compound 2; then compound 3; then compound 4.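

In this assay, the anilino ring turns out to be sensitive to substitution: putting trifluoromethyl in place of hydrogen on one of its aromatic carbons, meta to a large group, gives a 25-fold higher number from compound 2 to compound 4 (1.40 log units; beyond the scatter) and so moves the compound far towards weaker activity. Within the data shown here, the only earlier step, made on the aromatic nitrogen, was much smaller at a 4.0-fold higher number from compound 2 to compound 3 (0.60 log units; beyond the scatter) and gave no hint that this ring would matter more, even though the 4-methoxybenzyl group added there is the larger of the two additions. Nothing available here accounts for the size of this loss.

As far as these compounds go, with one substituent at one place on the ring, it stays open whether a fluorine, a methyl, a methoxy or an amine on the same carbon would raise the number as far, or whether the same groups elsewhere on the ring would behave differently. For compound 1 the entry reads "not determined" (no result reported) and so the step for trifluoromethyl in the series carrying the 4-methoxybenzyl group cannot be read.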